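This account rests on a few compounds, and the source may have more. Where it says the series, first, only, none or still open, it means among the compounds named here.

Going by the values given here, only two compounds have been tested so far in an ADME assay on THP-1 cells (Homo sapiens) for cytotoxicity, read by trypan blue exclusion, with a stated time of 48 h (a higher number here means a weaker inhibitor of growth, a lower number a stronger inhibitor of growth), and their numbers sit well apart. Compound 1 `Cc1c(CNCc2ccccc2)cc(-c2ccc(Cl)cc2)n1-c1ccc(Cl)cc1` gives 99 ug/mL while compound 2 `Cc1cc(CNCc2ccc(F)cc2)c(C)n1-c1ccc(Cl)cc1` gives 8.4 ug/mL and so holds the lower number of the pair, with a gap beyond the usual scatter of such measurements.

The next compound to be tested, compound 3 `Cc1ccc(CNCc2cc(C)n(-c3ccc(Cl)cc3)c2C)cc1`, differs from compound 2 in one place, where 4-fluorobenzyl becomes 4-methylbenzyl. This is methyl in place of fluoro on an aromatic carbon, para to a large group, and the exchange counts as methyl in place of fluoro on an aromatic carbon in full.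

Among the compounds with values here, no pair of tested compounds shows this exchange, so the data offer no direct guide to its size or direction. The closest reference is compound 2 at 8.4 ug/mL as the starting point. With nothing to favour either direction, the expected result is a 1.1-fold higher number from compound 2 to compound 3 (0.03 log units; within the scatter) and this estimated change stays within the usual scatter. The estimated value for compound 3 is 9 ug/mL with an expected range from 4 ug/mL to 22 ug/mL for this measurement.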

Compound 3, concentration for 50% growth inhibition: 6.1 ug/mL
Beside the measured number, compound 3's estimate is 1.5-fold (0.17 log units) above it; the range from low to high includes it.
By their numbers in this assay, from the lowest: compounds 3 and 2 (each within the scatter of the next); then compound 1.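

Going by these compounds alone, exchanging fluoro for methyl on an aromatic carbon gives the first direct reading at this position: in this assay, going from 4-fluorobenzyl to 4-methylbenzyl gives a 1.4-fold lower number from compound 2 to compound 3 (0.14 log units; within the scatter). The two compounds therefore cannot be told apart in this measurement, so replacing this one-heavy-atom group with another leaves no clear mark on the read-out at this place, para to a large group. Nothing measured alongside this result speaks to why the two numbers sit so close together.

On these data alone, a single exchange at one position is a narrow test, and it says nothing about groups that differ more from these two, so it remains open whether a carboxylic acid, an amine or a methoxy group at the same place would also stay within the scatter of compound 2. Also open, as far as these compounds go, are what a longer chain such as propyl would do there and whether the same fluoro-to-methyl exchange would read the same way on the core of compound 1.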